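Series notes: heterocycle swap on the chain of the shared core

A few compounds are considered here, and "the series" means these few. Any claim that something is new, unique, unknown or untested is made for them only; others in the source may bear on it.

Measured so far:
- compound 1 `Nc1ncn(CCC2(N)OC(=O)C(OCc3ccccc3)=C2OCc2ccccc2)c(=O)n1`; in a functional assay on HeLa cells (Homo sapiens) for inhibition, read by MTT assay, with a stated time of 72 h (on this read-out lower numbers stand for stronger inhibition and higher numbers for weaker inhibition), compound 1 gives > 100000 nM, a limit only.
- compound 2 `NC1(CCn2cc(F)c(=O)[nH]c2=O)OC(=O)C(OCc2ccccc2)=C1OCc1ccccc1`; in this assay compound 2 gives > 100000 nM, a limit only.
- compound 3 `Cc1cn(CCC2(N)OC(=O)C(OCc3ccccc3)=C2OCc2ccccc2)c(=O)[nH]c1=O`; in this assay compound 3 gives > 100000 nM, a limit only.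

Where compound 3 stands: its value in this assay is a limit, not a number, and the same holds for the other two compounds, all three sitting at the limit of > 100000 nM in this assay, at which 3 of the 3 values shown sit. Among the compounds with values here, no compound in the set can be ranked against another.

The steps among the measured compounds are a step that the two limits leave unreadable from compound 1 to compound 2, a step that the two limits leave unreadable from compound 1 to compound 3 and a step that the two limits leave unreadable from compound 2 to compound 3. None of them has a readable size, so the set carries no information on how a change of the ring group on the chain moves the read-out.

The next compound is compound 4 `NC1(CCn2c(=O)[nH]c(=O)[nH]c2=O)OC(=O)C(OCc2ccccc2)=C1OCc1ccccc1`. It differs from compound 3 by a group of 9 heavy atoms (3 carbon, 3 nitrogen, 3 oxygen; one six-membered aromatic ring with 3 hetero atoms) in place of a group of 9 heavy atoms (5 carbon, 2 nitrogen, 2 oxygen; one six-membered aromatic ring with 2 hetero atoms), on a saturated chain carbon, two bonds along the chain from a saturated ring carbon. Within the data shown here, the steps that bear on this change are those between compound 1, compound 2 and compound 3, which alter the same ring group, and each of them is unreadable. No step beyond the scatter can therefore be predicted; the expected outcome is that compound 4 stays at the limit as well.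

Compound 4 is expected to give about 150000 nM in this assay, with a range from 50000 nM to 500000 nM. The expected step is a step that the limit leaves unreadable from compound 3 to compound 4, that is, no change that the assay would resolve.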

Compound 4, half-maximal inhibitory concentration: 77100 nM
For compound 4 the middle estimate is 1.9-fold (0.29 log units) above the measured one; low and high end bracket the measured number.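

Within the data shown here, compound 4 is the first compound with a number rather than a limit in this assay, which ties a ring group on a saturated chain carbon, two bonds along the chain from a saturated ring carbon, to a value inside the measured range. Its steps are floors only, an at least 1.2-fold lower number from compound 3 to compound 4 (0.11 log units; that floor lies within the scatter), an at least 1.2-fold lower number from compound 2 to compound 4 (0.11 log units; that floor lies within the scatter) and an at least 1.2-fold lower number from compound 1 to compound 4 (0.11 log units; that floor lies within the scatter), so none of them is shown to lie beyond the scatter and their true sizes remain unknown. Compound 1 also carries one six-membered aromatic ring with 3 hetero atoms, so that ring count alone does not separate compound 4 from the compounds that stay at the limit: the limit of > 100000 nM in this assay, at which 3 of the 4 values shown sit.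

The steps among compound 1, compound 2 and compound 3 cannot be read, which leaves those three ring groups without an order. Also open, as far as these compounds go, is whether a longer chain bearing the ring group of compound 4, or an amine or a carboxylic acid in its place, would give a number that differs from compound 4 by more than the scatter.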